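Swapping Acetyl for Cyano on the Aromatic Ring

This account rests on a few compounds, and the source may have more. Where it says the series, first, only, none or still open, it means among the compounds named here.

Of the compounds shown here, three sharing one core have been measured in an ADME assay on a cell-free system (plasma, Homo sapiens) for metabolic stability, read by HPLC; a higher number here means that the compound lasts longer, a lower number that the compound disappears faster. For the measured compounds named here, compound 1 `CN(/N=N/c1ccc(C#N)cc1)C(=O)CCc1ccc(O)cc1` gives 5.8 h, and compound 3 `COC(=O)c1ccc(/N=N/N(C)C(=O)CCc2ccc(O)cc2)cc1` gives 7.3 h; the single step between them, a 1.3-fold higher number from compound 1 to compound 3 (0.10 log units; within the scatter), lies within the scatter. Compound 2 `CC(=O)c1ccc(/N=N/N(C)C(=O)CCCCc2ccc(O)cc2)cc1` gives 32.7 h, the highest of the three numbers, beyond the scatter from both compound 3 and compound 1. Compound 4 `CN(/N=N/c1ccc(C#N)cc1)C(=O)CCCCc1ccc(O)cc1` has not yet been measured. It differs from compound 2 in one place: cyano in place of acetyl on an aromatic carbon. Going by the values given here, no measured step covers this exact exchange of acetyl for cyano. The nearest guide is the exchange of one group for another on the same aromatic carbon between compound 1 and compound 3, which moved the half-life little. Compound 2 and compound 3 differ in two places at once, so their gap cannot be assigned to either change alone. Compound 4 is therefore expected to stay close to compound 2, with an expected step of a 1.3-fold lower number from compound 2 to compound 4 (0.12 log units; within the scatter). The estimate for compound 4 is 25 h, with a range from 10 h to 50 h.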

Compound 4, half-life: 11.8 h
Compound 4: the middle estimate sits 2.1-fold (0.33 log units) above what was measured; the range from low to high includes it.
By their numbers in this assay, from the lowest: compounds 1, 3 and 4 (each within the scatter of the next, the first and the last beyond it); then compound 2.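

In this assay, the exchange of acetyl for cyano on the aromatic carbon para to a large group gives a 2.8-fold lower number from compound 2 to compound 4 (0.44 log units; beyond the scatter), so the group at this place can shift the half-life beyond the scatter, which the earlier step, a 1.3-fold higher number from compound 1 to compound 3 (0.10 log units; within the scatter), did not show. That earlier step involved a different pair of groups, so the two results do not conflict, and the outcome here depends on which groups are exchanged. Acetyl and cyano have the same hydrogen-bond acceptor count, so that count does not separate compound 2 from compound 4, and no measurement at hand explains the drop.

On these data alone, it remains open how a carboxylic acid or an amine on this aromatic carbon would behave. Also open, as far as these compounds go, is whether the exchange of acetyl for cyano would give a step of similar size with the chain of compound 1 in place of the chain of compound 2.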